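Arylsulfonamide series: naphthyl substituent in place of nitrophenyl

The source may hold more compounds than are shown below. What is called first, only, known or untested is meant among the compounds shown, and "the series" means these compounds.

Compound 1 `N#CC1=C(N)N(c2ccc(S(N)(=O)=O)cc2)C2=C(C(=O)CCC2)C1c1ccccc1`: in a functional assay on Ehrlich cells (Mus musculus) for antiproliferative activity, read by trypan blue exclusion, with a stated time of 2 h (on this read-out higher numbers stand for weaker inhibition and lower numbers for stronger inhibition), compound 1 gives > 100 ug/mL, which is a limit of the assay rather than a number.
Compound 2 `N#CC1=C(N)N(c2ccc(S(N)(=O)=O)cc2)C2=C(C(=O)CCC2)C1c1cccc([N+](=O)[O-])c1`: in this assay compound 2 gives 25 ug/mL.

Among the measured compounds shown here, compound 2 holds the only number in this assay; the other value is a limit. Compound 3 `COc1ccc2ccccc2c1C1C(C#N)=C(N)N(c2ccc(S(N)(=O)=O)cc2)C2=C1C(=O)CCC2` carries the change (2-methoxynaphthalen-1-yl in place of 3-nitrophenyl on a saturated ring carbon). For the measured compounds named here, the one measured step, an at least 4.0-fold lower number from compound 1 to compound 2 (0.60 log units; beyond the scatter), concerns the nitro group that now leaves, so its loss is expected to move the number upward; the incoming group has no measured precedent. Compound 3 is therefore expected at 50 ug/mL, within 15 ug/mL to 150 ug/mL, a step of a 2.0-fold higher number from compound 2 to compound 3 (0.30 log units; within the scatter) that is estimated, not measured.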

Compound 3, half-maximal inhibitory concentration: 12.5 ug/mL
Estimate against measurement, compound 3: 4.0-fold (0.60 log units) above, and the stated range ends above it.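

In this assay, 2-methoxynaphthalen-1-yl and 3-nitrophenyl on the saturated ring carbon cannot be told apart, with a 2.0-fold lower number from compound 2 to compound 3 (0.30 log units; within the scatter). A nitro group is therefore not required at this position, and the aromatic group here can change substantially while activity is kept, with an at least 8.0-fold lower number from compound 1 to compound 3 (0.90 log units; beyond the scatter). Compound 1 stands at a limit of the assay, not a number: the limit of > 100 ug/mL in this assay, at which 1 of the 3 values shown sits.

Still open, on these data alone, is whether the methoxy group or the second aromatic ring accounts for the difference from phenyl. Also open, as far as these compounds go, is how an amine or a carboxylic acid on the aromatic ring at this position would read.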